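The source may hold more compounds than are shown below. What is called first, only, known or untested is meant among the compounds shown, and "the series" means these compounds.

Measured so far:
- Compound 1 `COC(=O)C12CC1CCN(C(=O)[C@H](CC(C)C)NC(=O)[C@H](CO)NC(=O)[C@@H](NC(=O)OCc1ccccc1)C(C)C)C2`: in an ADME assay on a cell-free system (plasma, Homo sapiens) for metabolic stability (on this read-out higher numbers stand for a longer-lived compound and lower numbers for a shorter-lived compound), compound 1 gives 2.47 h.
- Compound 2 `COC(=O)C12CC1CCN(C(=O)[C@H](CC(C)C)NC(=O)[C@H](CO)NC(=O)[C@@H](NC(=O)c1cccc(O)c1C)C(C)C)C2`: in this assay compound 2 gives > 6 h, which is a limit of the assay rather than a number.

Compound 2 therefore stands at the top of what has been seen here, sitting at the limit of > 6 h in this assay, at which 1 of the 2 values shown sits. Within the data shown here, the only measured step, an at least 2.4-fold higher number from compound 1 to compound 2 (0.38 log units; beyond the scatter), shows that exchanging the group on the carbonyl carbon can move the half-life by a noticeable amount.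

The next step leads to compound 3 `COC(=O)C12CC1CCN(C(=O)[C@H](CC(C)C)NC(=O)[C@H](CO)NC(=O)[C@@H](NC(=O)C1=CCCNC1)C(C)C)C2`. Its change is a group of 6 heavy atoms (5 carbon, 1 nitrogen; one six-membered non-aromatic ring with 1 hetero atom) in place of a group of 8 heavy atoms (7 carbon, 1 oxygen; one six-membered aromatic ring of carbon only), on a carbonyl carbon. Among the measured compounds shown here, no measured step covers an exchange of this kind, since the one step measured swaps in an aromatic ring rather than removing one, so it offers only a rough guide that this position matters for the read-out. A step of modest size, downward from the limit, is expected; compound 3 is expected to give 4.5 h in this assay, with a range from 2 h to 10 h, which corresponds to an expected change of an at least 1.3-fold lower number from compound 2 to compound 3 (0.12 log units; that floor lies within the scatter).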

Compound 3, half-life: 4.92 h
For compound 3 the middle estimate is 1.1-fold (0.04 log units) below the measured one, within the range that was stated.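

In this assay, among these compounds, this result shows that a carbonyl carbon bearing a six-membered non-aromatic ring with one nitrogen, rather than an aromatic ring, can still give a half-life of the same order as the earlier compounds. The step of an at least 1.2-fold lower number from compound 2 to compound 3 (0.08 log units; that floor lies within the scatter) gives only a floor, so it cannot establish a real loss on replacing the 3-hydroxy-2-methylphenyl group, and the read-out for compound 2 remains a limit and not a number: the limit of > 6 h in this assay, at which 1 of the 3 values shown sits. The other comparison, a 2.0-fold higher number from compound 1 to compound 3 (0.30 log units; within the scatter), means that this pair cannot be told apart, so the new ring gives no clear gain over the benzyloxy group.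

The compounds shown leave open whether the ring nitrogen or the double bond of the new group matters for the half-life, as these two features are not varied separately here. They also leave open how the read-out would respond on this carbonyl carbon to a fully saturated piperidine ring, an open-chain amine or a carboxylic acid.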